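Adding a Third Methoxy Group to a Shared Core

The source may hold more compounds than are shown below. What is called first, only, known or untested is meant among the compounds shown, and "the series" means these compounds.

Among the compounds with values here, compound 1, `COc1ccc(CNc2nc3cc(N)cc(N)c3nc2-c2ccccc2)cc1OC`, is one of two compounds measured in a functional assay on ACHN cells (Homo sapiens) for inhibition, read by sulforhodamine B assay, with a stated time of 48 h; a higher number here means a weaker inhibitor of growth, a lower number a stronger inhibitor of growth. Compound 1 gives 13800 nM, the lower of the two numbers. Compound 2, `CCOC(=O)[C@H](CCC(=O)O)NC(=O)c1ccc(Sc2nc3cc(N)cc(N)c3nc2-c2ccccc2)cc1`, gives 36300 nM in this assay, a gap that lies beyond the usual scatter. Compound 3, `COc1cc(CNc2nc3cc(N)cc(N)c3nc2-c2ccccc2)cc(OC)c1OC`, carries one more group: methoxy in place of hydrogen on an aromatic carbon. Within the data shown here, no step of this kind between measured compounds is available, so the expectation rests on compound 1 alone. The step of a 1.2-fold lower number from compound 1 to compound 3 (0.06 log units; within the scatter) is expected to be small, with no clear direction beyond the scatter. Compound 3 is therefore estimated at 12000 nM, within a range from 5000 nM to 30000 nM.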

Compound 3, concentration for 50% growth inhibition: 5370 nM
Compound 3: the middle estimate sits 2.2-fold (0.35 log units) above what was measured; low and high end bracket the measured number.
By their numbers in this assay, from the lowest: compound 3; then compound 1; then compound 2.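

The added methoxy group gives a 2.6-fold lower number from compound 1 to compound 3 (0.41 log units; beyond the scatter) in this assay, so growth inhibition is sensitive to a change at this aromatic carbon, ortho to a methoxy group and meta to a large group. Within the data shown here, this is the first step that changes one place only, and here the added group strengthens growth inhibition rather than weakening it. Nothing available explains this gain. Going by these compounds, whether an amine, a hydroxyl group or a longer ethoxy chain at this carbon would act like methoxy remains open. So does the effect of a carboxylic acid there.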